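Shifting a trifluoromethyl group on a phenyl ring

The source may hold more compounds than are shown below. What is called first, only, known or untested is meant among the compounds shown, and "the series" means these compounds.

Compound 1 `C/C(=C\CC/C(C)=C/CC[C@@H]1[C@@]2(C)CCC(=O)C(C)(C)[C@H]2CC[C@@]1(C)O)CC/C=C(\C)C(=O)OCc1cn(-c2ccccc2C(F)(F)F)nn1` carries a 2-(trifluoromethyl)phenyl on an aromatic nitrogen of its shared core. In a functional assay on DU-145 cells (Homo sapiens) for antiproliferative activity, read by MTT assay, with a stated time of 48 h (on this read-out lower numbers stand for stronger inhibition and higher numbers for weaker inhibition), compound 1 gives only a limit of the assay, > 150000 nM. Compound 2 `C/C(=C\CC/C(C)=C/CC[C@@H]1[C@@]2(C)CCC(=O)C(C)(C)[C@H]2CC[C@@]1(C)O)CC/C=C(\C)C(=O)OCc1cn(-c2ccc(F)c(Cl)c2)nn1` has a 3-chloro-4-fluorophenyl in place of that 2-(trifluoromethyl)phenyl on the aromatic nitrogen. In this assay compound 2 likewise gives only a limit, > 150000 nM. The step that the two limits leave unreadable from compound 1 to compound 2 thus has no readable size, as both values sit at the limit of > 150000 nM in this assay, at which 2 of the 2 values shown sit. Compound 3 `C/C(=C\CC/C(C)=C/CC[C@@H]1[C@@]2(C)CCC(=O)C(C)(C)[C@H]2CC[C@@]1(C)O)CC/C=C(\C)C(=O)OCc1cn(-c2cccc(C(F)(F)F)c2)nn1` is not yet measured; it differs from compound 1 by 3-(trifluoromethyl)phenyl in place of 2-(trifluoromethyl)phenyl on an aromatic nitrogen. Among the compounds with values here, the single measured step offers no size and no direction to carry over, and with both measured compounds resting at the limit of > 150000 nM in this assay, at which 2 of the 2 values shown sit, compound 3 is expected to give 150000 nM in this assay, within a range of 50000 nM to 400000 nM, most probably again as a limit. The expected step is a number no higher from compound 1 to compound 3 (the limit leaves the size open).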

Compound 3, half-maximal inhibitory concentration: > 150000 nM
Compound 3 was reported as a limit; the forecaster's own chance of this, stated with the estimate: 75%; the middle value lies on the limit itself.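

Compound 3 also gives only a limit in this assay, so its steps from compound 1 and from compound 2 cannot be read: the limit of > 150000 nM in this assay, at which 3 of the 3 values shown sit. The compounds shown leave open whether any of these phenyl groups on the aromatic nitrogen changes the activity at all.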